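Cytotoxicity series: three amides level, a fourth to come

A few compounds are considered here, and "the series" means these few. Any claim that something is new, unique, unknown or untested is made for them only; others in the source may bear on it.

Measured compounds:
compound 1 `O=C(Nc1cccc(Oc2ccccn2)c1)C1CCCN(C(=O)c2cc(C(F)(F)F)cc(C(F)(F)F)c2)C1`, 0%
compound 2 `COC(=O)c1cccc(NC(=O)C2CCCN(C(=O)c3cc(C(F)(F)F)cc(C(F)(F)F)c3)C2)c1`, 0%
compound 3 `Cn1cnnc1-c1cccc(NC(=O)C2CCCN(C(=O)c3cc(C(F)(F)F)cc(C(F)(F)F)c3)C2)c1`, 0%

In an ADME assay on PC-3 cells (Homo sapiens) for cytotoxicity, read by WST assay, tested at 100 uM (on this read-out lower numbers stand for less inhibition and higher numbers for more inhibition at the one concentration tested (going by the name of the read-out)), compound 1 gives 0%. In this assay compound 2 gives 0%, and compound 3 gives 0%. Compound 3 therefore stands level with compounds 1 and 2, the three sharing the same core and varying only at one aromatic carbon.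

Going by the values given here, the steps so far bearing on that position are no change at the digits printed from compound 1 to compound 2 (within the scatter), no change at the digits printed from compound 1 to compound 3 (within the scatter) and no change at the digits printed from compound 2 to compound 3 (within the scatter). None of the three exchanges at this carbon moved the read-out beyond the scatter.

Compound 4 `O=C(Nc1cccc(Oc2nccc(C(F)(F)F)c2Cl)c1)C1CCCN(C(=O)c2cc(C(F)(F)F)cc(C(F)(F)F)c2)C1` is the next member. It differs from compound 3 as follows: (3-chloro-4-(trifluoromethyl)pyridin-2-yl)oxy in place of 4-methyl-4H-1,2,4-triazol-3-yl on an aromatic carbon. The group entering is larger than any tried here, but the three measured exchanges at this carbon all left this assay flat, so no step beyond the scatter is expected either way. The step from compound 3 to compound 4 is estimated at no change at the digits printed from compound 3 to compound 4 (within the scatter). Compound 4 is expected to give 0% in this assay, within a range of -10% to 15%.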

Compound 4, a percentage reported as inhibition, at one concentration (the size of the read-out at that concentration, not a potency): 0%
The estimate for compound 4 equals the measured number at the digits printed, within the range that was stated.
By their numbers in this assay, from the lowest: compounds 1, 2, 3 and 4 (each within the scatter of the next).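

In this assay, the exchange of 4-methyl-4H-1,2,4-triazol-3-yl for the larger (3-chloro-4-(trifluoromethyl)pyridin-2-yl)oxy, with 12 heavy atoms against 6, leaves the read-out flat (no change at the digits printed from compound 3 to compound 4 (within the scatter)), and the exchange from methoxycarbonyl does the same (no change at the digits printed from compound 2 to compound 4 (within the scatter)). Replacing pyridin-2-yl on the oxygen with 3-chloro-4-(trifluoromethyl)pyridin-2-yl also leaves it flat (no change at the digits printed from compound 1 to compound 4 (within the scatter)), so the flat range at this aromatic carbon now includes a group carrying chlorine and trifluoromethyl. No measurement at hand explains this flat result.

From the compounds shown here alone, whether an amine or a carboxylic acid at this aromatic carbon would shift the read-out remains open. Also open, going by these compounds, is what a change to the shared core would do, since all four compounds keep it intact.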